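Aryl ketone variation on the shared core: step to compound 4

The compounds below may be only part of what the source reports. "The series", "measured", "known", "first", "only" and "open" are said of these compounds alone.

Compound 3 `COc1ccc(C(=O)/C=C/c2cc(-c3cc(OC)c(OC)c(OC)c3)n[nH]2)cc1` stands second highest of the three numbers in a functional assay on TK-10 cells (Homo sapiens) for inhibition, read by sulforhodamine B assay, with a stated time of 48 h (a lower number here means a stronger inhibitor of growth, a higher number a weaker inhibitor of growth), where compound 3 gives 2220 nM. Nearest is compound 2 `COc1ccc(C(=O)/C=C/c2cc(-c3cc(OC)c(OC)c(OC)c3)n[nH]2)cc1OC`, which in this assay gives 1330 nM; the step of a 1.7-fold higher number from compound 2 to compound 3 (0.22 log units; within the scatter) lies within the scatter. Furthest is compound 1 `COc1cc(-c2cc(/C=C/C(=O)c3ccc(N)cc3)[nH]n2)cc(OC)c1OC`, which in this assay gives 4840 nM; the step of a 2.2-fold lower number from compound 1 to compound 3 (0.34 log units; beyond the scatter) is beyond the scatter, as is the step of a 3.6-fold lower number from compound 1 to compound 2 (0.56 log units; beyond the scatter).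

Compound 4 `COc1cc(-c2cc(/C=C/C(=O)c3ccc(F)c(F)c3)[nH]n2)cc(OC)c1OC` differs from compound 3 by 3,4-difluorophenyl in place of 4-methoxyphenyl on a carbonyl carbon. Of the measured steps, a 2.2-fold lower number from compound 1 to compound 3 (0.34 log units; beyond the scatter) and a 3.6-fold lower number from compound 1 to compound 2 (0.56 log units; beyond the scatter) concern the same ring on the carbonyl carbon and were modest in size, while a 1.7-fold higher number from compound 2 to compound 3 (0.22 log units; within the scatter) at that ring was within the scatter. Among the measured compounds shown here, no measured step brings fluorine into this ring, so the present change has no direct precedent among the three compounds, and the measured steps at this ring give no consistent direction. The expected step of a 1.1-fold higher number from compound 3 to compound 4 (0.05 log units; within the scatter) is therefore small, with no direction claimed beyond the scatter. Compound 4 is estimated at 2500 nM in this assay, with a range from 900 nM to 7000 nM.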

Compound 4, concentration for 50% growth inhibition: 2290 nM
Estimate against measurement, compound 4: 1.1-fold (0.04 log units) above; the measured number falls inside the stated range.
By their numbers in this assay, from the lowest: compounds 2, 3 and 4 (each within the scatter of the next); then compound 1.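

Notes on the ring on the carbonyl carbon: in this assay, 3,4-difluorophenyl, with no hydrogen-bond acceptor, reads the same within the scatter as the methoxy-bearing rings, at a 1.0-fold higher number from compound 3 to compound 4 (0.01 log units; within the scatter) and a 1.7-fold higher number from compound 2 to compound 4 (0.24 log units; within the scatter), so fluorine on this ring and removal of the acceptor counted on the 4-methoxyphenyl shift the number by no more than the scatter. Compound 1 now stands apart from three different rings rather than two: alongside its steps to compound 2 and compound 3, a 2.1-fold lower number from compound 1 to compound 4 (0.33 log units; beyond the scatter) is beyond the scatter, and none of the compounds shown goes against this separation of the 4-aminophenyl compound from the others. The available data offer no measurement that explains either the flat readings or the separate position of compound 1.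

Still open, on these data alone, is whether any ring on the carbonyl carbon gives a number clearly below those of compound 2, compound 3 and compound 4, for example one bearing a single fluorine, a chlorine, a trifluoromethyl group, a hydroxyl group or a carboxylic acid. Also open, as far as these compounds go, is whether an amine other than the primary amino group of compound 1, such as a dimethylamino group, gives a number like that of compound 1 or like those of the other three.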